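Swapping an Aryl Amide for a Small Ring: Toxicity Outlook

The source may hold more compounds than are shown below. What is called first, only, known or untested is meant among the compounds shown, and "the series" means these compounds.

Measured so far:
compound 1 `Cc1cc(C)cc(NC(=O)COc2cc(C)nc3ccc(OC(F)(F)F)cc23)c1`, > 100000 nM;
compound 2 `COc1ccc2nc(C)cc(OCC(=O)Nc3ccc(Br)c(C)c3)c2c1`, 15900 nM;
compound 3 `COc1ccc2nc(C)cc(OCC(=O)Nc3cc(OC)c(Cl)cc3OC)c2c1`, > 100000 nM.

Among the compounds with values here, in a toxicity assay on HepG2 cells (Homo sapiens) for inhibition, read by CellTiter-Glo, with a stated time of 48 h (on this read-out higher numbers stand for weaker inhibition and lower numbers for stronger inhibition), compound 2 gives 15900 nM, the only plain number among the three. For compound 1 the result is only a limit, > 100000 nM. For compound 3 the result is likewise only a limit, > 100000 nM. Both sit at the limit of > 100000 nM in this assay, at which 2 of the 3 values shown sit.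

Compound 4 `COc1ccc2nc(C)cc(OCC(=O)NC3CONC3=O)c2c1` has not been measured. It differs from compound 2 in one place: a group of 6 heavy atoms (3 carbon, 1 nitrogen, 2 oxygen; one five-membered non-aromatic ring with 2 hetero atoms) in place of a group of 8 heavy atoms (7 carbon, 1 bromine; one six-membered aromatic ring of carbon only), on an amide-type nitrogen. Within the data shown here, no measured pair shows a change of this kind, so the size of the step is a guess. Weaker inhibition is expected, a step of a 5.0-fold higher number from compound 2 to compound 4 (0.70 log units; beyond the scatter), perhaps ending at the limit. Compound 4 is estimated at 80000 nM, ranging from 25000 nM to 300000 nM.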

Compound 4, half-maximal inhibitory concentration: > 100000 nM
Compound 4 ended at the assay's limit; the forecaster's own chance of this, stated with the estimate: 55%; at least 1.2-fold (0.09 log units) between middle value and limit.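

In this assay, placing the five-membered non-aromatic ring on the amide-type nitrogen instead of the 4-bromo-3-methylphenyl group gives an at least 6.2-fold higher number from compound 2 to compound 4 (0.79 log units; beyond the scatter). This is the only single-place comparison shown, and it links this change to weaker inhibition in these cells. The result for compound 4 is a limit, so the full size of the step stays unknown: the limit of > 100000 nM in this assay, at which 3 of the 4 values shown sit.

From the compounds shown here alone, it remains open whether losing the bromine or replacing the aromatic ring matters more. A plain phenyl or a cyclopentyl group on that nitrogen could separate the two.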